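The source may hold more compounds than are shown below. What is called first, only, known or untested is meant among the compounds shown, and "the series" means these compounds.

In an in vitro assay on COS-7 cells for displacement of a labelled ligand from prostaglandin D2 receptor 2 (Homo sapiens) (on this read-out higher numbers stand for weaker inhibition and lower numbers for stronger inhibition), compound 1 `O=C(O)Cc1sc(-c2ccccc2)nc1-c1ccc(F)cc1` gives 860 nM, the highest of the three numbers recorded. Compound 2 `O=C(O)Cc1sc(-c2ccccc2)nc1-c1ccc(-c2ccccc2)cc1` gives 38 nM in this assay, and compound 3 `O=C(O)Cc1sc(Cc2ccc(Cl)cc2)nc1-c1ccc(Cl)cc1` gives 50 nM. The only single-point step among these is a 23-fold lower number from compound 1 to compound 2 (1.35 log units; beyond the scatter), but that change sits on the 4-fluorophenyl side of the shared core and not at the position altered here. Compound 4 `O=C(O)Cc1sc(Cc2ccccc2)nc1-c1ccc(F)cc1` differs from compound 1 in one place: benzyl in place of phenyl on an aromatic carbon. For the measured compounds named here, no measured step follows exactly this change. Compound 3 carries a 4-chlorobenzyl at the same position and gives a far lower number than compound 1, yet it also differs at the other aromatic ring, so its two values can only hint at the direction. On that hint alone, a moderate drop in this assay is expected, in the form of a 2.9-fold lower number from compound 1 to compound 4 (0.46 log units; beyond the scatter). Compound 4 is therefore estimated at 300 nM, with a range from 80 nM to 1200 nM.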

Compound 4, half-maximal inhibitory concentration: 140 nM
For compound 4 the middle estimate is 2.1-fold (0.33 log units) above the measured one; low and high end bracket the measured number.
By their numbers in this assay, from the lowest: compounds 2 and 3 (each within the scatter of the next); then compound 4; then compound 1.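

In this assay, the change from phenyl to benzyl gives a 6.1-fold lower number from compound 1 to compound 4 (0.79 log units; beyond the scatter) while the 4-fluorophenyl and carboxymethyl groups stay the same. For the compounds shown here, this is the first clean reading at this position, on the aromatic carbon next to the ring nitrogen and the ring sulfur, and it shows that the number responds to what is attached there. Keeping the aromatic ring but placing a carbon chain unit in front of it is enough to carry the step beyond the scatter.

From the compounds shown here alone, it remains open whether a longer chain such as phenylethyl, or an amine joining the phenyl to the shared core, would lower the number further. Going by these compounds, it is also open whether benzyl would give a similar step alongside the group that compound 2 carries in place of 4-fluorophenyl.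

No measurement at hand gives a reason for the step.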